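Toward compound 4: a pyridyl swap on the biaryl amide

The source may hold more compounds than are shown below. What is called first, only, known or untested is meant among the compounds shown, and "the series" means these compounds.

Compound 1 `CCN1[C@H](C)CN(c2cc3c(cc2OC)CCN3C(=O)c2ccc(-c3cccc(C)n3)c3ccccc23)C[C@@H]1C` gives 126 nM in an assay on isolated protein for binding affinity to 5-hydroxytryptamine receptor 1D (Homo sapiens); on this read-out higher numbers stand for weaker inhibition and lower numbers for stronger inhibition.
Compound 2 `CCCN1[C@H](C)CN(c2cc3c(cc2OC)CCN3C(=O)c2ccc(-c3cccc(C)n3)c3ccccc23)C[C@@H]1C` gives 158 nM in this assay.
Compound 3 `COc1cc2c(cc1N1C[C@@H](C)N[C@@H](C)C1)N(C(=O)c1ccc(-c3ccc(C(C)=O)cc3C)cc1)CC2` gives 398 nM in this assay.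

Compound 3 stands highest of the three numbers, beyond the scatter from both compound 2 and compound 1. Compound 4 `COc1cc2c(cc1N1C[C@@H](C)N[C@@H](C)C1)N(C(=O)c1ccc(-c3cc(C)ncc3C)cc1)CC2` differs from compound 3 by 2,5-dimethylpyridin-4-yl in place of 4-acetyl-2-methylphenyl on an aromatic carbon. Within the data shown here, the only measured step, a 1.3-fold higher number from compound 1 to compound 2 (0.10 log units; within the scatter), concerns an alkyl group on the saturated ring and does not bear on an aryl exchange of this kind, so no measured step informs the change directly. With nothing in the data to anchor a direction, the step of a 1.3-fold lower number from compound 3 to compound 4 (0.12 log units; within the scatter) is expected to stay small, and compound 4 is estimated at 300 nM, within 100 nM to 900 nM.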

Compound 4, inhibition constant: 501 nM
Estimate against measurement, compound 4: 1.7-fold (0.22 log units) below, within the range that was stated.
By their numbers in this assay, from the lowest: compounds 1 and 2 (each within the scatter of the next); then compounds 3 and 4 (each within the scatter of the next).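

At this position, on an aromatic carbon para to a large group, 2,5-dimethylpyridin-4-yl in place of 4-acetyl-2-methylphenyl gives a 1.3-fold higher number from compound 3 to compound 4 (0.10 log units; within the scatter) in this assay. The acetyl group leaves and a ring nitrogen enters, yet the read-out does not separate the two compounds. Nothing measured here accounts for this result. Going by these compounds, it remains open whether an amine or a carboxylic acid in place of the acetyl group on the phenyl ring would move the number beyond the scatter.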